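Replacing the propylcarbamoyl group of compound 3

The source may hold more compounds than are shown below. What is called first, only, known or untested is meant among the compounds shown, and "the series" means these compounds.

In a functional assay on cells (Platelet, Homo sapiens) for inhibition (on this read-out lower numbers stand for stronger inhibition and higher numbers for weaker inhibition), compound 1 `CCCOC(=O)c1ccc(-c2nn(Cc3ccccc3)c3ccccc23)cc1` gives > 10000 nM as a limit. Compound 2 `CNC(=O)c1ccc(-c2nn(Cc3ccccc3)c3ccccc23)cc1` gives > 10000 nM as a limit too. Compound 3 `CCCNC(=O)c1ccc(-c2nn(Cc3ccccc3)c3ccccc23)cc1` likewise gives > 10000 nM as a limit, so it offers no number to start from. All three stand together, as the limit of > 10000 nM in this assay, at which 3 of the 3 values shown sit, shows.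

Compound 4 `CO/N=C\c1ccc(-c2nn(Cc3ccccc3)c3ccccc23)cc1` changes the group on an aromatic carbon: a group of 4 heavy atoms (2 carbon, 1 nitrogen, 1 oxygen; no ring) in place of a group of 6 heavy atoms (4 carbon, 1 nitrogen, 1 oxygen; no ring), on an aromatic carbon is the difference. The measured changes are a step that the two limits leave unreadable from compound 1 to compound 2 and a step that the two limits leave unreadable from compound 1 to compound 3 and a step that the two limits leave unreadable from compound 2 to compound 3 and they give no size to carry over.

Neither direction can be firmly expected, so the estimated change is a step that the limit leaves unreadable from compound 3 to compound 4 and no more than that. Compound 4 is expected at about 12000 nM with an estimated range of 3000 nM to 40000 nM and will most likely return a limit again.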

Compound 4, half-maximal inhibitory concentration: > 10000 nM
Compound 4 gave a limit, no number; the forecaster's own chance of this, stated with the estimate: 75%; the middle value does not contradict the limit.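

Compound 4, like compounds 1, 2 and 3, returns only a limit, so no step among these compounds can be read: the limit of > 10000 nM in this assay, at which 4 of the 4 values shown sit.

In this assay the compounds shown leave open whether any group at this place on the shared core gives a measurable value.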